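This account rests on a few compounds, and the source may have more. Where it says the series, first, only, none or still open, it means among the compounds named here.

Of the compounds shown here, three that share one core have been tested so far in a functional assay on NCI-H520 cells (Homo sapiens); on this read-out lower numbers stand for stronger inhibition of growth and higher numbers for weaker inhibition of growth. Compound 1 `O=S(=O)(/C=C/c1ccccc1)Cc1ccc(Nc2ncnc3ccccc23)cc1` gives > 100000 nM, which is a limit of the assay and not a number. Compound 2 `N#Cc1ccc(/C=C/S(=O)(=O)Cc2ccc(Nc3ncnc4ccccc34)cc2)cc1` gives > 100000 nM, which is again a limit. Among the measured compounds shown here, compound 3 `O=S(=O)(/C=C/c1ccc(Cl)cc1Cl)Cc1ccc(Nc2ncnc3ccccc23)cc1` gives 12000 nM, the only true number in the set, and so the only firm starting point.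

Placing a 2,4-dichlorophenyl group on the double-bonded chain carbon accounts for the two steps that can be sized, an at least 8.3-fold lower number from compound 1 to compound 3 (0.92 log units; beyond the scatter) and an at least 8.3-fold lower number from compound 2 to compound 3 (0.92 log units; beyond the scatter). Compound 4 `O=S(=O)(/C=C/c1ccc(Cl)cc1Cl)Cc1ccc(Nc2ncnc3ccc(Br)cc23)cc1` leaves that group untouched and changes another part of the molecule: bromo in place of hydrogen on an aromatic carbon. It carries bromo in place of hydrogen on an aromatic carbon, on a ring that is part of a fused system.

Neither measured step involves this place, so neither gives a size that can be carried over. The expectation therefore rests on compound 3 at 12000 nM, and no step beyond the scatter is expected in this assay, though with wide uncertainty in both directions. The expected change is a 1.2-fold lower number from compound 3 to compound 4 (0.08 log units; within the scatter). For compound 4 the estimated value is 10000 nM, with an expected range of 2500 nM to 40000 nM.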

Compound 4, concentration for 50% growth inhibition: 8000 nM
The estimate for compound 4 lay 1.3-fold (0.10 log units) above the measured number; the range from low to high includes it.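

In this assay, among the compounds shown here, the earlier steps all concerned the group on the double-bonded chain carbon, and this is the first reading for a change on the fused part of the core: a 1.5-fold lower number from compound 3 to compound 4 (0.18 log units; within the scatter). Compound 3 and compound 4 therefore cannot be told apart in this assay, so adding bromo, a single heavy atom with no ring and no net charge, at this aromatic carbon gives no measurable difference against the 2,4-dichlorophenyl background. This is also the only step in the set at this place that can be read, and the steps involving compound 1 and compound 2 that meet a limit of the assay on both sides cannot be read: the limit of > 100000 nM in this assay, at which 2 of the 4 values shown sit.

Bromo is the only group shown at this carbon, so it remains open how an amine, a carboxylic acid or a longer chain would read there. Also open, on these data alone, is whether bromo at this place would bring compound 1 or compound 2 away from their limit; here it appears only together with the 2,4-dichlorophenyl group.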